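The source may report more compounds than this note shows. Statements on the series, on what has been measured and on what is new or still open speak of the compounds shown alone.

Working notes on the thiazolidinedione series.

Compound 1 `COc1cc(-n2c(C)cc(/C=C3\SC(=O)NC3=O)c2C)ccc1-c1ccc(/C=C2\SC(=O)NC2=O)cc1` carries two thiazolidinedione ene units on a shared core. In an assay for inhibition of glutaminase kidney isoform, mitochondrial (Homo sapiens), read by coupled enzyme assay, with stated times of 10 min and 60 min (on this read-out higher numbers stand for weaker inhibition and lower numbers for stronger inhibition), compound 1 gives 243 nM, the highest of the two numbers in hand. Compound 2 `CCc1cc(-c2ccc(-n3c(-c4ccccc4)cc(/C=C4\SC(=O)NC4=O)c3-c3ccccc3)cc2)ccc1/C=C1\SC(=O)NC1=O` differs from compound 1 in several places; in this assay compound 2 gives 56 nM, and the two values show compound 2 with the lower number.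

Compound 3 `Cc1cc(/C=C2\SC(=O)NC2=O)c(C)n1-c1ccc(-c2ccc(/C=C3\SC(=O)NC3=O)cc2)cc1` is compound 1 with hydrogen in place of methoxy on an aromatic carbon; the change is a hydrogen in place of methoxy on an aromatic carbon. Among the measured compounds shown here, no single-point step between measured compounds exists to size this. The step from compound 1 to compound 3 is expected to be small, within scatter, giving a 1.0-fold higher number from compound 1 to compound 3 (0.01 log units; within the scatter). Compound 3 is estimated at 250 nM, in the range 100 nM to 650 nM.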

Compound 3, half-maximal inhibitory concentration: 102 nM
Beside the measured number, compound 3's estimate is 2.5-fold (0.39 log units) above it, and the stated range covers the measured number.
By their numbers in this assay, from the lowest: compounds 2 and 3 (each within the scatter of the next); then compound 1.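

Among the compounds shown here, this is the first one-place step: in this assay, hydrogen in place of methoxy gives a 2.4-fold lower number from compound 1 to compound 3 (0.38 log units; beyond the scatter), a modest change. Methoxy is therefore not required on this aromatic carbon for inhibition, and hydrogen gives the lower number here. No supporting evidence bears on why the number moves. Still open, going by these compounds, is how fluorine, a hydroxyl group or a longer ether such as ethoxy would read on this carbon, and whether the step is the same on a core other than that of compound 1.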